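The compounds below may be only part of what the source reports. "The series", "measured", "known", "first", "only" and "open" are said of these compounds alone.

Compound 1, `CC(C)Nc1nc(N)nc2c1ncn2/C=C1/CC1(CO)CO`: > 24000 nM
Compound 2, `CCCCOc1nc(N)nc2c1ncn2/C=C1/CC1(CO)CO`: > 20000 nM

In an ADME assay on Akata cells (Homo sapiens) for cytotoxicity, with a stated time of 7 days (a higher number here means that more compound is tolerated, a lower number that less compound is tolerated), compound 1 gives > 24000 nM, which is a limit of the assay rather than a number. Compound 2 likewise gives only a limit of > 20000 nM. The single measured step, a step that the two limits leave unreadable from compound 1 to compound 2, therefore stays unreadable because both values sit at limits (the limit of > 20000 nM in this assay, at which 1 of the 2 values shown sits, (the limit of > 24000 nM in this assay, at which 1 of the 2 values shown sits)), and nothing in the shown data tells how large a change at this position of the shared core can be.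

Compound 3, `Nc1nc(SCc2ccccc2)c2ncn(/C=C3/CC3(CO)CO)c2n1`, has not yet been measured. It differs from compound 1 by benzylsulfanyl in place of isopropylamino on an aromatic carbon. Going by the values given here, no measured step bears on this change with a readable size, so no direction beyond the scatter can be expected from the data. Compound 3 is estimated to give 15000 nM in this assay, with a range from 3000 nM to 40000 nM. The expected step of an at least 1.6-fold lower number from compound 1 to compound 3 (0.20 log units; that floor lies within the scatter) is thus an estimate only, carrying wide uncertainty.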

Compound 3, half-maximal cytotoxic concentration: > 20000 nM
Compound 3: no number, only a limit (the forecaster's own chance of this, stated with the estimate: 50%); at least 1.3-fold (0.12 log units) between middle value and limit.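

Compound 3 gives > 20000 nM in this assay and this is again a limit of the assay, not a number, so its steps from compound 1 and compound 2 cannot be read: the limit of > 20000 nM in this assay, at which 2 of the 3 values shown sit. The compounds shown leave open whether changing this group on the shared core alters cytotoxicity at all.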